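A Double Bond Redrawn: From Compound 2 to Compound 4

A few compounds are considered here, and "the series" means these few. Any claim that something is new, unique, unknown or untested is made for them only; others in the source may bear on it.

Compound 1, `CC/C(=C(/c1ccc(NC(=O)C(C)C)cc1)c1ccc(OC)cc1)c1ccc(OCc2ccccc2)cc1`, gave 29000 nM in a functional assay on MCF7 cells (Homo sapiens) for inhibition, read by trypan blue exclusion, with a stated time of 72 h; a higher number here means a weaker inhibitor of growth, a lower number a stronger inhibitor of growth. Compound 2, `CC/C(=C(/c1ccc(NC(=O)C(C)C)cc1)c1ccc(OC)cc1)c1ccc(O)cc1`, gave 13600 nM in this assay. Compound 3, `CC/C(=C(/c1ccc(NC(=O)C(C)C)cc1)c1ccc(OC)cc1)c1ccc(Cl)cc1Cl`, gave 6600 nM in this assay.

Compound 2 holds the second highest of the three numbers. Compound 1 sits above it: a 2.1-fold lower number from compound 1 to compound 2 (0.33 log units; beyond the scatter). Compound 3 sits below it: a 2.1-fold lower number from compound 2 to compound 3 (0.31 log units; beyond the scatter). Both of these steps come from exchanging one group for another at the ring carried by the shared core.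

Compound 4, `CC/C(=C(\c1ccc(NC(=O)C(C)C)cc1)c1ccc(OC)cc1)c1ccc(O)cc1`, is not yet measured. Set against compound 2, (the two compounds have the same atoms and bonds and differ only in configuration as drawn: 1 of 1 stereo elements differ; a double bond is drawn E in compound 2 and Z in compound 4). Within the data shown here, neither measured step involves a change of configuration; each swaps a substituent while the drawn geometry stays the same, so no measured step bears on this change. Nothing in the data shows how this assay responds to a redrawn double bond, and the direction of any step is therefore open. Compound 4 is expected to give 14000 nM, within a wide range from 3500 nM to 56000 nM, which is an expected step of a 1.0-fold higher number from compound 2 to compound 4 (0.01 log units; within the scatter).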

Compound 4, concentration for 50% growth inhibition: 9000 nM
Compound 4: the middle estimate sits 1.6-fold (0.19 log units) above what was measured, and the stated range covers the measured number.
By their numbers in this assay, from the lowest: compounds 3, 4 and 2 (each within the scatter of the next, the first and the last beyond it); then compound 1.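

The earlier steps shown here each swapped a substituent with the drawn geometry held fixed, whereas this pair isolates the geometry of the double bond, because nothing else separates the two compounds: the fact that compounds 2 and 4 differ only in the configuration as drawn. In this assay, redrawing the double bond gives a 1.5-fold lower number from compound 2 to compound 4 (0.18 log units; within the scatter). That step lies within the scatter, so this assay does not tell the two drawn geometries apart for this pair, and the change has no resolved effect of the kind seen in the two substituent swaps.

The compounds shown leave open whether the same would hold with the benzyl ether of compound 1 or the 2,4-dichlorophenyl of compound 3 in the redrawn geometry. They also leave open how an amine or a carboxylic acid in place of the hydroxyl of compound 2 and compound 4 would read in either geometry.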